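The source may hold more compounds than are shown below. What is called first, only, known or untested is meant among the compounds shown, and "the series" means these compounds.

Series notes. Within the data shown here, in a functional assay on BJAB cells (Homo sapiens) for antiproliferative activity, with a stated time of 4 days (a higher number here means that more compound is needed for the effect, a lower number that less compound is needed), compound 1 `Cc1nn(-c2nc(-c3ccc(Cl)c(Cl)c3)c(SC(C)C)s2)c(C(=O)O)c1Cc1ccccc1[N+](=O)[O-]` gives 20000 nM, the second highest of the three numbers so far. Compound 2 `Cc1ccccc1-c1c(C)nn(-c2nc(-c3ccc(Cl)c(Cl)c3)c(SC(C)C)s2)c1C(=O)O` gives 5500 nM, and compound 3 `COC(=O)c1c(Cc2ccccc2[N+](=O)[O-])c(C)nn1-c1nc(-c2ccc(Cl)c(Cl)c2)c(SC(C)C)s1` gives 93000 nM. Compound 4 `Cc1cc(-c2c(C)nn(-c3nc(-c4ccc(Cl)c(Cl)c4)c(SC(C)C)s3)c2C(=O)O)cc(C)n1` carries the change (2,6-dimethylpyridin-4-yl in place of 2-nitrobenzyl on an aromatic carbon). The step that bears on it is a 3.6-fold lower number from compound 1 to compound 2 (0.56 log units; beyond the scatter), where another aromatic ring likewise replaced the 2-nitrobenzyl group on an aromatic carbon; the step of a 4.7-fold higher number from compound 1 to compound 3 (0.67 log units; beyond the scatter) concerns the carboxy group only and says nothing about this position. Among the measured compounds shown here, no other step in this assay touches the replaced group. For compound 4 a modest lower number is therefore expected, estimated as a 2.9-fold lower number from compound 1 to compound 4 (0.46 log units; beyond the scatter). The value expected for compound 4 is 7000 nM, with a range from 2500 nM to 20000 nM.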

Compound 4, half-maximal effective concentration: 580 nM
Estimate against measurement, compound 4: 12-fold (1.08 log units) above; the measured number lies below the stated range.
By their numbers in this assay, from the lowest: compound 4; then compound 2; then compound 1; then compound 3.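

The carbon that held the 2-nitrobenzyl group accepts a directly attached six-membered aromatic ring with one hetero atom, and this change brings a 34-fold lower number from compound 1 to compound 4 (1.54 log units; beyond the scatter). The two aromatic replacements are not interchangeable, since 2,6-dimethylpyridin-4-yl in place of 2-methylphenyl still gives a 9.5-fold lower number from compound 2 to compound 4 (0.98 log units; beyond the scatter). Nothing measured here speaks to the origin of this gap.

Whether the ring nitrogen or the two methyl groups account for the step stays open. So does the outcome at this position with an unsubstituted pyridine ring or a phenyl ring bearing an amine.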